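Imidazopyrazine series: aryl swap from compound 3 to compound 4

This account rests on a few compounds, and the source may have more. Where it says the series, first, only, none or still open, it means among the compounds named here.

Measured compounds:
- compound 1 `Fc1ccc(-c2cn3ccnc3c(-c3ccc4ncn(C5CCCCC5)c4c3)n2)cc1`, 7.36%
- compound 2 `c1cn2cc(-c3ccsc3)nc(-c3ccc4ncn(C5CCCCC5)c4c3)c2n1`, 25%
- compound 3 `CCc1ccc(-c2cn3ccnc3c(-c3ccc4ncn(Cc5ccccc5)c4c3)n2)cc1`, 47.9%

In a functional assay on SK-MEL-5 cells (Homo sapiens) for inhibition, read by sulforhodamine B assay, with a stated time of 48 h, tested at 10 uM (a higher number here means more inhibition at the concentration tested (going by the name of the read-out), a lower number less inhibition), compound 3 gives 47.9%, the highest of the three numbers; compound 2 sits nearest, and compound 1 furthest below, both gaps beyond the scatter. For the measured compounds named here, compound 3 also differs from compound 1 and compound 2 at the other end of the shared core, so no single step separates it from either; only the values themselves can be compared.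

Compound 4 `O=Cc1ccc(-c2cn3ccnc3c(-c3ccc4ncn(Cc5ccccc5)c4c3)n2)cc1` is not yet measured. It differs from compound 3 by formyl in place of ethyl on an aromatic carbon.

Going by the values given here, the one measured step, a number 17.6 percentage points higher from compound 1 to compound 2 (beyond the scatter), concerns the same aromatic position but exchanges one ring for another and does not involve a formyl or an ethyl group, so it bears on the change only by showing that substitution at this place moves the read-out by a modest amount. Among the compounds with values here, no step that replaces ethyl with formyl is available.

The step of a number 12.9 percentage points lower from compound 3 to compound 4 (beyond the scatter) is therefore expected to be of modest size, with the direction uncertain and a somewhat lower number thought slightly more likely. For compound 4 the estimate in this assay is 35%, within 10% to 60%.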

Compound 4, a percentage reported as inhibition, at one concentration (the size of the read-out at that concentration, not a potency): 56.5%
The estimate for compound 4 lay 21.5 percentage points below the measured number; the range from low to high includes it.
By their numbers in this assay, from the lowest: compound 1; then compound 2; then compounds 3 and 4 (each within the scatter of the next).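

In this assay, going from 4-ethylphenyl to 4-formylphenyl gives a number 8.6 percentage points higher from compound 3 to compound 4 (within the scatter), so at this place, on an aromatic carbon para to a large group, the read-out does not separate ethyl from formyl. The earlier step at this place, a number 17.6 percentage points higher from compound 1 to compound 2 (beyond the scatter), exchanged one whole ring for another, whereas this step keeps the six-membered aromatic ring and changes only the group on it; the formyl brings a hydrogen-bond acceptor and a double bond outside aromatic rings, and the read-out at the single tested concentration stays within the scatter. No measurement at hand bears on why ethyl and formyl read alike here.

On these data alone, whether other groups at this place would also stay within the scatter of compound 3 remains open, for example an amine, a carboxylic acid or a longer chain. Also open is whether the same exchange would read alike with the group that compound 1 and compound 2 carry at the other end of the shared core, since the step shown here rests on one pair of compounds.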